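A urea-for-amide switch on the azetidine oxadiazole series

This account rests on a few compounds, and the source may have more. Where it says the series, first, only, none or still open, it means among the compounds named here.

Compound 1 `O=C(c1ccccc1F)N1CC[C@H]1c1nc(-c2cccc(F)c2)no1` in an assay on HEK293 cells for positive allosteric modulation of metabotropic glutamate receptor 5 (Homo sapiens), read by FLIPR (on this read-out lower numbers stand for an effect already at smaller amounts and higher numbers for an effect only at larger amounts of compound), gives only a limit, > 10000 nM.
Compound 2 `CC1CCCC(C(=O)N2CC(c3nc(-c4cccc(Cl)c4)no3)C2)C1` in this assay gives 410 nM.
Compound 3 `CC1CCC(C(=O)N2CC(c3nc(-c4cccc(Cl)c4)no3)C2)CC1` in this assay gives 1500 nM.

Among the compounds with values here, compound 3 holds the highest of the two numbers; its nearest neighbour is compound 2, and that step, a 3.7-fold higher number from compound 2 to compound 3 (0.56 log units; beyond the scatter), is the only measured step here. Compound 4 `O=C(N1CCC(F)CC1)N1CC(c2nc(-c3cccc(Cl)c3)no2)C1` differs from compound 3 by 4-fluoropiperidin-1-yl in place of 4-methylcyclohexyl on a carbonyl carbon. Within the data shown here, no measured step covers a change of this kind, since the single step from compound 2 to compound 3 moves only a methyl around the same ring. The expectation for compound 4 therefore rests on compound 3 alone, with a step of no change at the digits printed from compound 3 to compound 4 (within the scatter) expected and no direction claimed. Compound 4 is estimated in this assay at 1500 nM, within 300 nM to 8000 nM.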

Compound 4, half-maximal effective concentration: 990 nM
The estimate for compound 4 lay 1.5-fold (0.18 log units) above the measured number; the measured number falls inside the stated range.
By their numbers in this assay, from the lowest: compound 2; then compounds 4 and 3 (each within the scatter of the next). At a limit, above all of these: compound 1.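

In this assay, within the data shown here, a ring with a hetero atom on this carbonyl carbon is tolerated, a point the earlier compounds could not show: a 1.5-fold lower number from compound 3 to compound 4 (0.18 log units; within the scatter) stays within the scatter. The position is still not indifferent to the group it carries, since a 2.4-fold higher number from compound 2 to compound 4 (0.38 log units; beyond the scatter) leaves 3-methylcyclohexyl ahead of 4-fluoropiperidin-1-yl. Nothing shown here bears on the cause of either step. The compounds shown leave open whether 3-fluoropiperidin-1-yl would match 3-methylcyclohexyl, and whether a morpholine at this place would hold the number of compound 4.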